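Working notes: from compound 3 to compound 4

The source may report more compounds than this note shows. Statements on the series, on what has been measured and on what is new or still open speak of the compounds shown alone.

Compound 1 `Cc1ccc(-c2c[nH]cn2)cc1NC(=O)c1ccc(OCc2ccccn2)cc1` and compound 2 `Cc1ccc(-c2ncc[nH]2)c(C)c1NC(=O)c1ccc(OCc2ccccn2)cc1` have both been measured in a physicochemical assay for lipophilicity; a higher number here means a more lipophilic compound, a lower number a more polar compound: compound 1 gives 2.8 and compound 2 gives 2.8. Compound 3 `Cc1cc(C)c(-c2nc3ccccc3[nH]2)cc1NC(=O)c1ccc(OCc2ccccn2)cc1` reaches only a limit of this assay, > 3.5, so no number stands for it; this is the situation described by the limit of > 3.5 in this assay, at which 1 of the 3 values shown sits. Among the compounds with values here, with no number for compound 3, no step between measured compounds can be sized. Compound 4 `Cc1cc(C)c(-c2cccc(N)n2)cc1NC(=O)c1ccc(OCc2ccccn2)cc1` differs from compound 3 by 6-aminopyridin-2-yl in place of 1H-benzimidazol-2-yl on an aromatic carbon. The step from compound 3 to compound 4 is expected to be downward, a number at least 0.50 log units lower from compound 3 to compound 4 (beyond the scatter), beyond the scatter. Compound 4 is estimated at 3 in this assay, within a range from 2.5 to 3.5.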

Compound 4, distribution coefficient: > 3
Compound 4: a limit, no number; the forecaster's own chance of this, stated with the estimate: 15%; the middle value sits exactly at the limit.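

Within the data shown here, compound 3 and compound 4 each give only a limit in this assay, not a number, so no step between them can be read. The compounds shown leave open whether, and how far, 6-aminopyridin-2-yl in place of 1H-benzimidazol-2-yl changes the distribution coefficient.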